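Acetamide-Bearing Analogue With a Benzodioxin Amide

The source may report more compounds than this note shows. Statements on the series, on what has been measured and on what is new or still open speak of the compounds shown alone.

Measured so far:
Compound 1 `Nc1cccc2c(-c3cccc(NC(=O)c4ccc5c(c4)OCCO5)c3)ccnc12`: 110 nM
Compound 2 `CC(=O)Nc1cccc2c(-c3cccc(NC(=O)c4ccc(Cl)c(C(F)(F)F)c4)c3)ccnc12`: 2400 nM

In a functional assay on UACC-62 cells (Homo sapiens) for antiproliferative activity, read by sulforhodamine B assay, with a stated time of 48 h (on this read-out lower numbers stand for stronger inhibition and higher numbers for weaker inhibition), compound 2 gives the highest of the two numbers; its nearest neighbour, compound 1, sits beyond the scatter. Compound 3 `CC(=O)Nc1cccc2c(-c3cccc(NC(=O)c4ccc5c(c4)OCCO5)c3)ccnc12` is the next one. From compound 2 it differs in one place: 2,3-dihydro-1,4-benzodioxin-6-yl in place of 4-chloro-3-(trifluoromethyl)phenyl on a carbonyl carbon. Among the compounds with values here, compound 3 shares that amide group with compound 1 and the acetamide with compound 2, and no single-change step separates them, so the two changes cannot be apportioned. A lower number is expected for compound 3, with the step from compound 2 estimated at a 4.8-fold lower number from compound 2 to compound 3 (0.68 log units; beyond the scatter), landing near 500 nM, within 120 nM to 2500 nM.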

Compound 3, half-maximal inhibitory concentration: 68 nM
For compound 3 the middle estimate is 7.4-fold (0.87 log units) above the measured one; measured number outside the range, below it.
By their numbers in this assay, from the lowest: compounds 3 and 1 (each within the scatter of the next); then compound 2.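

In this assay, 2,3-dihydro-1,4-benzodioxin-6-yl in place of 4-chloro-3-(trifluoromethyl)phenyl on the carbonyl carbon gives a 35-fold lower number from compound 2 to compound 3 (1.55 log units; beyond the scatter) with the acetamide held constant, so this single change carries a large step. With that amide group fixed, acetyl in place of hydrogen on the nitrogen gives a 1.6-fold lower number from compound 1 to compound 3 (0.21 log units; within the scatter) and thus no change beyond the scatter. No measurement shown here accounts for the size of the larger step.

Still open, as far as these compounds go, is how a plain phenyl or a pyridine would fare on that carbonyl carbon, and how a propanoyl or methanesulfonyl group would compare with acetyl on the nitrogen.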